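From a flexible amide chain to a cyclopropane amide

This account rests on a few compounds, and the source may have more. Where it says the series, first, only, none or still open, it means among the compounds named here.

For the measured compounds named here, compound 2 `CNC(=O)CCc1ccc(NCc2cccc(Oc3ccccc3)c2)cc1` is one of only two compounds measured so far. Going by the values given here, in a functional assay on CHO cells for agonist activity at Free fatty acid receptor 1 (Homo sapiens), read by a luciferase reporter (a higher number here means a larger maximal response, a lower number a smaller maximal response), compound 2 gives 67%, and its sole neighbour, compound 1 `O=C(O)CCCc1ccc(NCc2cccc(Oc3ccccc3)c2)cc1`, gives 59% in this assay. Among the compounds with values here, the one measured step, a number 8 percentage points higher from compound 1 to compound 2 (within the scatter), lies within the scatter, so the two numbers cannot be told apart. Compound 3 `CC(C)NC(=O)[C@H]1C[C@@H]1c1ccc(NCc2cccc(Oc3ccccc3)c2)cc1` changes the same end of the molecule more deeply: 2-(isopropylcarbamoyl)cyclopropyl in place of 2-(methylcarbamoyl)ethyl on an aromatic carbon. The entering 2-(isopropylcarbamoyl)cyclopropyl brings one three-membered non-aromatic ring of carbon only and 2 defined stereocentres. Within the data shown here, no measured step covers a change of this kind; only a number 8 percentage points higher from compound 1 to compound 2 (within the scatter) touches this part of the molecule, and that step was small. The maximal response of compound 3 is therefore expected to remain close to that of compound 2, with an expected step of a number 2 percentage points lower from compound 2 to compound 3 (within the scatter). Compound 3 is estimated at 65%, within a range of 45% to 85%.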

Compound 3, largest response reached (reported as percent of maximum), in percent of the reference or control that the assay uses: 62%
Compound 3: the middle estimate sits 3 percentage points above what was measured; low and high end bracket the measured number.
By their numbers in this assay, from the lowest: compounds 1, 3 and 2 (each within the scatter of the next).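

At this position, on an aromatic carbon para to a large group, the open chain can give way to 2-(isopropylcarbamoyl)cyclopropyl, with its three-membered ring and 2 defined stereocentres, and the maximal response in this assay still cannot be told apart: the result is a number 5 percentage points lower from compound 2 to compound 3 (within the scatter). The comparison with the acid-bearing chain gives the same reading, a number 3 percentage points higher from compound 1 to compound 3 (within the scatter), so 3-carboxypropyl, 2-(methylcarbamoyl)ethyl and the cyclopropane amide all fall within the usual scatter of one another. No measurement here accounts for this similarity.

Still open, going by these compounds, is whether the cyclopropane with its two stereocentres arranged the opposite way would stay within the scatter of compound 3. On these data alone, it is also open whether a primary amine, a cyclobutane ring or a longer chain at this position would shift the maximal response beyond it.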